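The source may hold more compounds than are shown below. What is called first, only, known or untested is meant among the compounds shown, and "the series" means these compounds.

Measured compounds:
- compound 1 `O=C(CCCCC1CCSS1)NCc1cn(CCCCOc2ccc3cc(-c4ccc(Cl)c(Cl)c4)c(=O)oc3c2)nn1`: 69.5%
- compound 2 `O=C(CCCCC1CCSS1)NCc1cn(CCCCCOc2ccc3ccc(=O)oc3c2)nn1`: 84.9%
- compound 3 `CC(=O)c1cc2ccc(OCCCCCn3cc(CNC(=O)CCCCC4CCSS4)nn3)cc2oc1=O`: 18.2%

In a functional assay on PC-12 cells (Rattus norvegicus) for cytotoxicity, read by MTT assay, with stated times of 3 h and 2 h, tested at 50 uM (on this read-out lower numbers stand for a weaker effect and higher numbers for a stronger effect at the one concentration tested), compound 3 stands lowest of the three measured compounds, with compound 1 the nearest and compound 2 the furthest above it, both beyond the scatter. Going by the values given here, the only single-site step among the measured compounds is a number 66.7 percentage points lower from compound 2 to compound 3 (beyond the scatter), where compound 3 carries an acetyl group on an aromatic carbon that bears a hydrogen in compound 2.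

Compound 4 `CCOC(=O)c1cc2ccc(OCCCCCn3cc(CNC(=O)CCCCC4CCSS4)nn3)cc2oc1=O` is not yet measured. It differs from compound 3 by ethoxy in place of methyl on a carbonyl carbon. Among the compounds with values here, no measured step touches this carbonyl substituent, so the one known step speaks only to the presence of a carbonyl group on that aromatic carbon, which compound 4 keeps. Compound 4 is therefore expected to stay close to compound 3 in this assay, with a step of a number 5.8 percentage points higher from compound 3 to compound 4 (within the scatter) that is estimated to remain within the scatter. For compound 4 the expected value in this assay is 24%, within a range from 8% to 50%.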

Compound 4, a percentage reported as activity, at one concentration (the size of the read-out at that concentration, not a potency): 40.7%
Beside the measured number, compound 4's estimate is 16.7 percentage points below it; the range from low to high includes it.
By their numbers in this assay, from the lowest: compound 3; then compound 4; then compound 1; then compound 2.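

In this assay, the group on the carbonyl carbon proves to matter, not just the presence of a carbonyl on the aromatic carbon: ethoxy in place of methyl gives a number 22.5 percentage points higher from compound 3 to compound 4 (beyond the scatter). Ethoxycarbonyl in place of hydrogen on the aromatic carbon still gives a number 44.2 percentage points lower from compound 2 to compound 4 (beyond the scatter), so compound 3 and compound 4 both lie below compound 2, but by an amount that depends on the group attached to the carbonyl carbon. Nothing available explains why ethoxy and methyl differ here.

The compounds shown leave open how a carboxylic acid, an amide or a longer alkoxy chain on that carbonyl carbon would read out. They also leave open whether the same change would give a step of similar size on the core of compound 1.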